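This account rests on a few compounds, and the source may have more. Where it says the series, first, only, none or still open, it means among the compounds named here.

Working notes on the series. Compound 1 `O=C(O)c1ccn(Cc2cc(Br)ccc2OCc2ccccc2)n1` gives in a functional assay on CHO-K1 cells for antagonist activity at prostaglandin E2 receptor EP1 subtype (Homo sapiens), read by FLIPR (a higher number here means a weaker inhibitor, a lower number a stronger inhibitor), a value of 55 nM. Going by the values given here, compound 2 `O=C(O)c1nn(Cc2cc(Br)ccc2OCc2ccccc2)cc1F` differs from compound 1 by fluoro in place of hydrogen on an aromatic carbon, and the step of a 13-fold higher number from compound 1 to compound 2 (1.10 log units; beyond the scatter) is the only measured step of this kind so far; in this assay compound 2 gives 692 nM. Compound 3 `Cc1cc(C(=O)O)nn1Cc1ccccc1OCc1ccc(Cl)cc1Cl` carries a different core, and the difference between the two cores is not broken down here; in this assay compound 3 gives 8.32 nM, the lowest of the three numbers. Compound 4 `Cc1cc(C(=O)O)nn1Cc1cc(F)ccc1OCc1ccc(Cl)cc1Cl` differs from compound 3 by fluoro in place of hydrogen on an aromatic carbon. This is the same kind of change as from compound 1 to compound 2, but not the same: there the fluoro entered a five-membered aromatic ring with 2 nitrogen, next to the ring atom that bears a carboxy group, whereas here it enters a six-membered aromatic ring of carbon only, meta to a large group and para to a large group. Compound 1 already bears a bromo at that same place on its own core, so a single fluorine there is not expected to move the number far; the step from compound 3 to compound 4 in this assay is estimated at a 1.2-fold higher number from compound 3 to compound 4 (0.08 log units; within the scatter), smaller than the earlier one. For compound 4 the expected value in this assay is 10 nM, with a range of 4 nM to 30 nM.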

Compound 4, inhibition constant: 20.4 nM
Estimate against measurement, compound 4: 2.0-fold (0.31 log units) below; the range from low to high includes it.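

In this assay, fluoro in place of hydrogen on an aromatic carbon gives a 2.5-fold higher number from compound 3 to compound 4 (0.39 log units; beyond the scatter), so the number rises on both cores, but the size of the rise does not carry from one core to the other: the same change on two cores in this assay, a 13-fold higher number (1.10 log units; beyond the scatter) from compound 1 to compound 2 and a 2.5-fold higher number (0.39 log units; beyond the scatter) from compound 3 to compound 4, 5.1-fold (0.71 log units) apart, beyond the scatter of two such steps

The fluoro also sits in a different place in each step, on a five-membered aromatic ring with 2 nitrogen in one and on a six-membered aromatic ring of carbon only in the other, and the compounds of the two pairs differ elsewhere too, so the gap cannot be assigned to any one of these differences. Two pairs show the direction for these compounds only and give no rule for a further core.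

As far as these compounds go, it remains open whether a chloro, a methoxy or a nitrile in place of the fluoro of compound 4 would give a similar step. Also open, from the compounds shown here alone, is how a fluoro on the five-membered aromatic ring of the core of compound 3 would compare.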